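The source may hold more compounds than are shown below. What is called first, only, known or untested is meant among the compounds shown, and "the series" means these compounds.

Of the compounds shown here, three sharing one core have been measured in a functional assay on MDA-MB-231 cells (Homo sapiens) for antiproliferative activity, read by MTT assay, with stated times of 72 h and 4 h; on this read-out higher numbers stand for weaker inhibition and lower numbers for stronger inhibition. Compound 1 `O=C(Nc1ccc(Cl)c(-c2nnc3c(Cl)cccn23)c1)c1ccc(F)cc1Cl` carries a 2-chloro-4-fluorophenyl group on the carbonyl carbon, and in this assay compound 1 gives 75000 nM. Compound 2 `O=C(Nc1ccc(Cl)c(-c2nnc3c(Cl)cccn23)c1)c1cccc(Cl)c1` carries a 3-chlorophenyl group in the same place, and in this assay compound 2 gives 66100 nM. Compound 3 `CS(=O)(=O)c1ccc(C(=O)Nc2ccc(Cl)c(-c3nnc4c(Cl)cccn34)c2)cc1` carries a 4-(methylsulfonyl)phenyl group there. In this assay compound 3 gives only a limit, > 100000 nM. Compound 3 therefore sits at the limit of > 100000 nM in this assay, at which 1 of the 3 values shown sits, with no plain number of its own, and the steps of an at least 1.3-fold higher number from compound 1 to compound 3 (0.12 log units; that floor lies within the scatter) and an at least 1.5-fold higher number from compound 2 to compound 3 (0.17 log units; that floor lies within the scatter) set only floors that lie within the scatter, as does the step of a 1.1-fold lower number from compound 1 to compound 2 (0.05 log units; within the scatter) between the two plain numbers.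

Compound 4 `Cc1cc(Cl)ccc1C(=O)Nc1ccc(Cl)c(-c2nnc3c(Cl)cccn23)c1` has not yet been measured. It differs from compound 3 in a single place: 4-chloro-2-methylphenyl in place of 4-(methylsulfonyl)phenyl on a carbonyl carbon. The two measured compounds that carry a chlorine-bearing phenyl group on the carbonyl carbon, compound 1 and compound 2, both return plain numbers close to each other. Compound 4 is therefore expected to give 70000 nM in this assay, with a range from 35000 nM to 150000 nM. The expected step is an at least 1.4-fold lower number from compound 3 to compound 4 (0.15 log units; that floor lies within the scatter), with a real chance that only a limit is reported again.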

Compound 4, half-maximal inhibitory concentration: > 100000 nM
Compound 4: no number, only a limit (the forecaster's own chance of this, stated with the estimate: 30%); middle value at least 1.4-fold (0.15 log units) from the limit.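

What compound 4 adds is that a chlorine-bearing phenyl group on the carbonyl carbon does not by itself return a plain number in this assay: with 4-chloro-2-methylphenyl in this place, compound 4 ends at a limit of the assay, just as compound 3 does with its 4-(methylsulfonyl)phenyl group, which has no chlorine. Against the two plain numbers the data give an at least 1.5-fold higher number from compound 2 to compound 4 (0.17 log units; that floor lies within the scatter) and an at least 1.3-fold higher number from compound 1 to compound 4 (0.12 log units; that floor lies within the scatter), so the true gap could be small or large and no real loss is shown yet. The step between compound 3 and compound 4 cannot be read, and the limit of the assay now holds more of this small set: the limit of > 100000 nM in this assay, at which 2 of the 4 values shown sit.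

Left open is whether a different kind of group on the phenyl ring at this place, such as an amine or a carboxylic acid, would give a number clearly lower than those of compound 1 and compound 2. The compounds shown also cannot tell whether the methyl or the chlorine of 4-chloro-2-methylphenyl matters, and a plain number for compound 4 would need testing at higher concentrations.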